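The source may report more compounds than this note shows. Statements on the series, on what has been measured and on what is new or still open speak of the compounds shown alone.

Measured so far in an ADME assay on MDCK-II cells (Canis lupus familiaris) for permeability; on this read-out higher numbers stand for higher permeability and lower numbers for lower permeability:
- compound 1 `O=C(O)c1ccc(CN2CCC[C@H](O[C@H](CO)c3cc(Cl)cc(Cl)c3)[C@@H]2c2ccccc2)c([N+](=O)[O-])c1`: 10 10^-6 cm/s
- compound 2 `Nc1cc(C(=O)O)ccc1CN1CCC[C@H](O[C@H](CO)c2cc(Cl)cc(Cl)c2)[C@@H]1c1ccccc1`: 21 10^-6 cm/s

Among the measured compounds shown here, compound 2 has the higher of the two numbers in this assay, at 21 10^-6 cm/s, and compound 1 is its only neighbour. The next compound to read is compound 3 `Cc1cc(C(=O)O)ccc1CN1CCC[C@H](O[C@H](CO)c2cc(Cl)cc(Cl)c2)[C@@H]1c1ccccc1`, which has methyl in place of amino on an aromatic carbon, ortho to a large group and meta to a carboxy group: methyl in place of amino on an aromatic carbon.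

For the measured compounds named here, one measured step bears on this change, as it touches the same aromatic carbon. It is a 2.1-fold higher number from compound 1 to compound 2 (0.32 log units; beyond the scatter), a modest step with amino in place of nitro. Going by the values given here, no measured compound yet carries methyl at this place, and a single step gives no trend, so the size of the new step rests on thin evidence. The modest size of a 2.1-fold higher number from compound 1 to compound 2 (0.32 log units; beyond the scatter) argues against expecting a large move.

The expected change is a 1.2-fold higher number from compound 2 to compound 3 (0.08 log units; within the scatter), which leans slightly upward and is not expected to go beyond the scatter. For compound 3 the estimated value is 25 10^-6 cm/s, with an expected range of 12 10^-6 cm/s to 50 10^-6 cm/s.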

Compound 3, apparent permeability in the MDCK-II assay: 22 10^-6 cm/s
For compound 3 the middle estimate is 1.1-fold (0.06 log units) above the measured one; low and high end bracket the measured number.
By their numbers in the MDCK-II assay, from the lowest: compound 1; then compounds 2 and 3 (each within the scatter of the next).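

In the MDCK-II assay, the exchange of amino for methyl, ortho to a large group and meta to a carboxy group, gives a 1.0-fold higher number from compound 2 to compound 3 (0.02 log units; within the scatter), so this read-out does not separate the two groups at this place. Methyl in place of nitro gives a 2.2-fold higher number from compound 1 to compound 3 (0.34 log units; beyond the scatter), which, alongside the earlier amino step, leaves compound 1 with nitro as the one compound set apart at this position, lower than both others. The exchange of amino for methyl does separate the two compounds in a physicochemical assay for solubility, in simulated intestinal fluid (a higher number here means a more soluble compound, a lower number a less soluble compound), where compound 2 gives 137000 nM and compound 3 gives 36000 nM as the lower number: the measured solubility of compound 2, 137000 nM, and of compound 3, 36000 nM, a 3.8-fold lower number (0.58 log units; beyond the scatter)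

With only nitro, amino and methyl at this carbon, the compounds shown leave open whether a methoxy, a chloro or a hydroxy group would stay level with amino and methyl in the MDCK-II assay or fall towards nitro, and whether any of them would keep the higher number of compound 2 in the physicochemical assay. They also leave open whether the same exchange would read the same way if a primary amide stood in place of the carboxy group.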